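The source may report more compounds than this note shows. Statements on the series, on what has been measured and on what is new or still open speak of the compounds shown alone.

Measured in an assay on liver for binding affinity to Alpha-1B adrenergic receptor (Homo sapiens), using microsomes; a higher number here means a weaker inhibitor, a lower number a stronger inhibitor:
compound 1 `COC(=O)C1=C(C)NC(=O)N(C(=O)NCCCN2CCN(c3ccccc3OC)CC2)C1c1ccc(F)c(F)c1`: 18 nM
compound 2 `COC(=O)C1=C(C)NC(=O)N(C(=O)NCCCN2CCN(c3ccc(Cl)cc3)CC2)C1c1ccc(F)c(F)c1`: 17 nM
compound 3 `COC(=O)C1=C(C)NC(=O)N(C(=O)NCCCN2CCN(c3cccc(Cl)c3)CC2)C1c1ccc(F)c(F)c1`: 8.4 nM

Compound 1 gives the highest number of the three; compound 2 sits within the scatter of it, while compound 3 lies beyond it. Compound 4 `COC(=O)C1=C(C)NC(=O)N(C(=O)NCCCN2CCN(c3cccc([N+](=O)[O-])c3)CC2)C1c1ccc(F)c(F)c1` is unmeasured; it differs from compound 1 by 3-nitrophenyl in place of 2-methoxyphenyl on an amine nitrogen in a ring. Among the measured compounds shown here, two measured steps bear on this change: a 2.1-fold lower number from compound 1 to compound 3 (0.33 log units; beyond the scatter) and a 2.0-fold lower number from compound 2 to compound 3 (0.31 log units; beyond the scatter), whereas a 1.1-fold lower number from compound 1 to compound 2 (0.02 log units; within the scatter). Only 3-chlorophenyl has so far moved the number beyond the scatter, and 3-nitrophenyl, though also entering on an amine nitrogen in a ring, is an untested group here, so in this assay a small shift toward a lower number, or none beyond the scatter, is expected. Compound 4 is therefore estimated at 12 nM, between 5 nM and 30 nM, with a 1.5-fold lower number from compound 1 to compound 4 (0.18 log units; within the scatter) expected.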

Compound 4, inhibition constant: 150 nM
The estimate for compound 4 lay 13-fold (1.10 log units) below the measured number; measured number outside the range, above it.
By their numbers in this assay, from the lowest: compound 3; then compounds 2 and 1 (each within the scatter of the next); then compound 4.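

In this assay, among the compounds shown here, the group on the amine nitrogen in a ring can shift the number much further than the earlier compounds showed: nitro in place of chloro on an aromatic carbon gives an 18-fold higher number from compound 3 to compound 4 (1.25 log units; beyond the scatter) and is the largest step. The 3-nitrophenyl group also separates from both other groups, with an 8.3-fold higher number from compound 1 to compound 4 (0.92 log units; beyond the scatter) and an 8.8-fold higher number from compound 2 to compound 4 (0.95 log units; beyond the scatter) in the same direction. No measurement at hand accounts for this rise.

From the compounds shown here alone, whether a nitrile or a methyl on that aromatic carbon would stay close to compound 3 or move toward compound 4 remains open.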